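Fluorophenyl Swaps on an Alkynyl Pyridine Amide Scaffold

The source may hold more compounds than are shown below. What is called first, only, known or untested is meant among the compounds shown, and "the series" means these compounds.

Three compounds share one core and differ only in the fluorophenyl group on a triple-bonded carbon. Compound 1 `C[C@@H](NC(=O)c1ccc(C#Cc2ccccc2F)cn1)C(C)(C)O` gives 29.6% in an ADME assay on HEK293 cells for agonist activity at metabotropic glutamate receptor 5 (Rattus norvegicus), read by fluorescence and calcium flux; a higher number here means a larger maximal response, a lower number a smaller maximal response. Compound 2 `C[C@@H](NC(=O)c1ccc(C#Cc2ccc(F)cc2)cn1)C(C)(C)O` gives 38.4% in this assay, and compound 3 `C[C@@H](NC(=O)c1ccc(C#Cc2cc(F)cc(F)c2)cn1)C(C)(C)O` gives 37.9% in this assay. Compound 3 stands alongside compound 2, the step of a number 0.5 percentage points lower from compound 2 to compound 3 (within the scatter) being within the scatter, and its distance to compound 1, a number 8.3 percentage points higher from compound 1 to compound 3 (within the scatter), is also within the scatter, so the three numbers are not separated by this assay.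

Compound 4 `C[C@@H](NC(=O)c1ccc(C#Cc2ccc(F)cc2F)cn1)C(C)(C)O` differs from compound 3 in one place: 2,4-difluorophenyl in place of 3,5-difluorophenyl on a triple-bonded carbon. Within the data shown here, the steps that bear on this change are the three fluorophenyl swaps already measured: a number 8.8 percentage points higher from compound 1 to compound 2 (within the scatter), a number 8.3 percentage points higher from compound 1 to compound 3 (within the scatter) and a number 0.5 percentage points lower from compound 2 to compound 3 (within the scatter). Every one of them stayed within the scatter, so a move from 3,5-difluorophenyl to 2,4-difluorophenyl on the triple-bonded carbon is expected to give no step beyond the scatter in this assay either, with at most a slight drift downward because compound 1, which carries a fluorine at the 2-position of the phenyl, gives 29.6%.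

Compound 4 is therefore estimated at 34% in this assay, within a range of 22% to 46%, and the expected step is a number 3.9 percentage points lower from compound 3 to compound 4 (within the scatter).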

Compound 4, largest response reached (reported as efficacy), in percent of the reference or control that the assay uses: 38.2%
Estimate against measurement, compound 4: 4.2 percentage points below; the measured number falls inside the stated range.
By their numbers in this assay, from the lowest: compounds 1, 3, 4 and 2 (each within the scatter of the next).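

In this assay, 2,4-difluorophenyl in place of 3,5-difluorophenyl on the triple-bonded carbon gives a number 0.3 percentage points higher from compound 3 to compound 4 (within the scatter) and shows that this rearrangement of the same atoms is not resolved by the read-out. Compound 4 can also be read as fluoro in place of hydrogen on an aromatic carbon from two starting points, with a number 0.2 percentage points lower from compound 2 to compound 4 (within the scatter) and with a number 8.6 percentage points higher from compound 1 to compound 4 (within the scatter) and, as both steps stay within the scatter, neither separates compound 4 from the compound with one fluorine. Nothing given here offers a reason for these numbers.

From the compounds shown here alone, it remains open whether a phenyl carrying a methoxy group, a nitrile or a chlorine on the triple-bonded carbon, or a phenyl with no fluorine at all, would give a step beyond the scatter in this assay. Going by these compounds, it is equally open whether a change elsewhere on the shared core, such as an amine in place of the hydroxyl, would separate these compounds in a way that the fluorine swaps do not.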